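A Five-Membered Ring in Place of Hydroxycarbamoyl

A few compounds are considered here, and "the series" means these few. Any claim that something is new, unique, unknown or untested is made for them only; others in the source may bear on it.

Compound 2 `N#Cc1c(N)nc(SCC(=O)NO)c(C#N)c1-c1ccc(OCC2CC2)cc1` stands highest of the two numbers measured in an assay on CHO cells for displacement of a labelled ligand from adenosine receptor A3 (Homo sapiens), read by scintillation counting, with a stated time of 120 min, tested at 1 uM (on this read-out lower numbers stand for less inhibition and higher numbers for more inhibition at the one concentration tested (going by the name of the read-out)), where compound 2 gives 31%. For the measured compounds named here, its nearest neighbour, compound 1 `N#Cc1c(N)nc(SCc2nnn[nH]2)c(C#N)c1-c1ccc(OCC2CC2)cc1`, gives 1% in this assay, and the step of a number 30 percentage points higher from compound 1 to compound 2 (beyond the scatter) is the only measured step available. Compound 3 `N#Cc1c(N)nc(SCC2=NCCN2)c(C#N)c1-c1ccc(OCC2CC2)cc1` differs from compound 2 in a single place: a group of 5 heavy atoms (3 carbon, 2 nitrogen; one five-membered non-aromatic ring with 2 hetero atoms) in place of a group of 4 heavy atoms (1 carbon, 1 nitrogen, 2 oxygen; no ring), on a saturated chain carbon bound to a sulfur. Going by the values given here, no measured step covers this exact exchange. Compound 3 is nevertheless expected to fall below compound 2 because a number 30 percentage points higher from compound 1 to compound 2 (beyond the scatter) came with the exchange of 1H-tetrazol-5-yl for hydroxycarbamoyl, and compound 3 again places a five-membered ring, though a non-aromatic one with different hetero atoms, on the saturated chain carbon bound to a sulfur. The estimated step for compound 3 is a number 16 percentage points lower from compound 2 to compound 3 (beyond the scatter), with uncertainty wide enough to include no change beyond the scatter. In this assay compound 3 is expected to give about 15%, within a range from 0% to 40%.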

Compound 3, a percentage reported as inhibition, at one concentration (the size of the read-out at that concentration, not a potency): 6%
For compound 3 the middle estimate is 9 percentage points above the measured one, within the range that was stated.
By their numbers in this assay, from the lowest: compounds 1 and 3 (each within the scatter of the next); then compound 2.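

In this assay, the exchange of hydroxycarbamoyl for the non-aromatic five-membered ring on the saturated chain carbon bound to a sulfur gives a number 25 percentage points lower from compound 2 to compound 3 (beyond the scatter), so a second ring group now stands against hydroxycarbamoyl. The two rings differ in aromatic character and in their hetero atoms, yet the exchange between them gives a number 5 percentage points higher from compound 1 to compound 3 (within the scatter). Among these three compounds, then, only the open-chain hydroxycarbamoyl stands apart from the others, and no information at hand accounts for this.

From the compounds shown here alone, it remains open whether the higher number is specific to hydroxycarbamoyl or would also appear with another open-chain group at this place, such as a carboxylic acid or a primary amide. Going by these compounds, whether a six-membered ring, such as morpholine, would behave like the two five-membered rings also remains open.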